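This account rests on a few compounds, and the source may have more. Where it says the series, first, only, none or still open, it means among the compounds named here.

Measured in a functional assay on NCI-H226 cells (Homo sapiens) for inhibition, read by sulforhodamine B assay, with a stated time of 48 h; on this read-out lower numbers stand for stronger inhibition of growth and higher numbers for weaker inhibition of growth:

Compound 1 `COc1ccc(-c2cc(/C=C/C(=O)c3ccc(N)cc3)[nH]n2)cc1`: 2000 nM
Compound 2 `COc1cc(-c2cc(/C=C/C(=O)c3ccc(N)cc3)[nH]n2)cc(OC)c1OC`: 1710 nM
Compound 3 `COc1ccc(C(=O)/C=C/c2cc(-c3cc(OC)c(OC)c(OC)c3)n[nH]2)cc1`: 1890 nM

All three compounds share one core and differ only in the groups on the two outer rings. Compound 2 gives the low end of the three numbers, but the gap to compound 3, a 1.1-fold higher number from compound 2 to compound 3 (0.04 log units; within the scatter), is within the scatter, and compound 1 also sits within the scatter of compound 2. In effect the three are indistinguishable in this assay.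

Compound 4 `COc1ccc(-c2cc(/C=C/C(=O)c3ccc(N)cc3)[nH]n2)cc1OC` is the next compound. It differs from compound 2 by hydrogen in place of methoxy on an aromatic carbon. Going by the values given here, no measured step removes a methoxy group directly. Among the compounds with values here, the only measured step, from compound 2 to compound 3, swaps a different group on the other ring and stays within the scatter. Compounds 1 and 2 carry one and three methoxy groups on that ring, yet their numbers are within scatter of each other, which suggests the count of methoxy groups matters little here. The expectation for compound 4 is therefore a 1.1-fold higher number from compound 2 to compound 4 (0.02 log units; within the scatter), no step beyond the scatter. Compound 4 is estimated at 1800 nM, with a range of 900 nM to 3600 nM.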

Compound 4, concentration for 50% growth inhibition: 2320 nM
For compound 4 the middle estimate is 1.3-fold (0.11 log units) below the measured one, within the range that was stated.
By their numbers in this assay, from the lowest: compounds 2, 3, 1 and 4 (each within the scatter of the next).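

Hydrogen and methoxy have now been compared directly at this position, which is ortho to a methoxy group and meta to a large group. In this assay, taking the methoxy group away gives a 1.4-fold higher number from compound 2 to compound 4 (0.13 log units; within the scatter), and putting one in place of hydrogen gives a 1.2-fold higher number from compound 1 to compound 4 (0.06 log units; within the scatter), so both one-place changes on this ring stay within the scatter and this assay cannot separate hydrogen from methoxy here. No independent measurement is available to explain this result.

The compounds shown leave open whether a different group at this position, such as a hydroxyl group, a chlorine atom or a longer chain like ethoxy, would shift the number beyond the scatter. They also leave open whether a dimethylamino group or a carboxylic acid there would do so.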